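The compounds below may be only part of what the source reports. "The series", "measured", "known", "first", "only" and "open" are said of these compounds alone.

Measured compounds:
compound 1 `CC(O)CC#Cc1c(Cl)c2c(Cl)cc(C(N)=O)nc2n1[C@H]1CCCNC1` — 48 nM
compound 2 `CC(C)(O)C#Cc1c(Cl)c2c(Cl)cc(C(N)=O)nc2n1[C@H]1CCCNC1` — 302 nM

Within the data shown here, in a functional assay on KG-1 cells (Homo sapiens) for antiproliferative activity (on this read-out higher numbers stand for an effect only at larger amounts of compound and lower numbers for an effect already at smaller amounts), compound 2 gives the higher of the two numbers; its nearest neighbour is compound 1, and the only measured step, a 6.3-fold higher number from compound 1 to compound 2 (0.80 log units; beyond the scatter), separates them. Compound 3 `NC(=O)c1cc(Cl)c2c(Cl)c(C#CCN3CCCC3=O)n([C@H]3CCCNC3)c2n1` is the next compound, and it differs from compound 2 in one place: (2-oxopyrrolidin-1-yl)methyl in place of 1-hydroxy-1-methylethyl on a triple-bonded carbon. Among the measured compounds shown here, no measured pair carries the entering group, so the only step that bears on the change is the one from compound 1 to compound 2, in which the 1-hydroxy-1-methylethyl group of compound 2 gave a markedly higher number than the 2-hydroxypropyl group of compound 1. Compound 3 carries neither of these groups on the triple-bonded carbon, so the step is not a direct reversal, and the direction is uncertain. Compound 3 is expected to move back toward compound 1, giving an estimated step of a 2.5-fold lower number from compound 2 to compound 3 (0.40 log units; beyond the scatter) in this assay. For compound 3 the estimated value is therefore 120 nM, with a range from 30 nM to 500 nM.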

Compound 3, half-maximal effective concentration: 178 nM
Beside the measured number, compound 3's estimate is 1.5-fold (0.17 log units) below it; measured number inside the range.
By their numbers in this assay, from the lowest: compound 1; then compounds 3 and 2 (each within the scatter of the next).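

In this assay the exchange on the triple-bonded carbon gives a 1.7-fold lower number from compound 2 to compound 3 (0.23 log units; within the scatter) even though the groups differ widely: the entering (2-oxopyrrolidin-1-yl)methyl has 7 heavy atoms, a five-membered non-aromatic ring and 0 hydrogen-bond donors, while the leaving 1-hydroxy-1-methylethyl has 4 heavy atoms, no ring and 1 hydrogen-bond donor. This position therefore takes these two quite different groups with numbers that cannot be told apart, and the presence of a hydrogen-bond donor does not separate compound 2 from compound 3. Set against the 2-hydroxypropyl compound, the other step reads a 3.7-fold higher number from compound 1 to compound 3 (0.57 log units; beyond the scatter) and leaves compound 1 with the lowest number of the three, its steps to both others lying beyond the scatter.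

The compounds shown leave open whether an amine on the same saturated chain carbon, a carboxylic acid or a longer hydroxyalkyl chain would reach or pass compound 1. They also leave open whether the order seen on these cells holds in any other read-out. No supporting data bear on why these numbers fall as they do.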